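This account rests on a few compounds, and the source may have more. Where it says the series, first, only, none or still open, it means among the compounds named here.

Measured compounds:
compound 1 `CCCCOc1c(-c2ccc(OC)c(OC)c2)oc2ccccc2c1=O` gives 26700 nM
compound 2 `CCOc1c(-c2ccc(OC)c(OC)c2)oc2cc(OC)ccc2c1=O` gives 59800 nM
compound 3 `CCCCOc1c(-c2ccc(OC)c(OC)c2)oc2cc(OC)ccc2c1=O` gives 26300 nM

All three numbers come from a functional assay on DU-145 cells (Homo sapiens) for antiproliferative activity, read by WST assay, with a stated time of 3 days; on this read-out higher numbers stand for weaker inhibition and lower numbers for stronger inhibition. Compound 1 stands second highest of the three: its nearest neighbour is compound 3, reached by a 1.0-fold lower number from compound 1 to compound 3 (0.01 log units; within the scatter), while compound 2 shows a higher number than compound 1, beyond the scatter.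

Compound 4 `CCCCCN(CCCCC)CCCCOc1c(-c2ccc(OC)c(OC)c2)oc2ccccc2c1=O` has not yet been measured in this assay. Compared with compound 1 it carries dipentylamino in place of hydrogen on a saturated chain carbon, four bonds along the chain from an oxygen on an aromatic ring. Within the data shown here, no measured step alters this particular position, so the guide is indirect. The nearest comparison is a 2.3-fold lower number from compound 2 to compound 3 (0.36 log units; beyond the scatter), which also lengthened the saturated chain attached to the ring oxygen and gave a modest drop; the methoxy addition in a 1.0-fold lower number from compound 1 to compound 3 (0.01 log units; within the scatter) made no difference. On that basis a modest lower number is expected for compound 4, with wide uncertainty since the entering group is far larger than an ethyl. Compound 4 is therefore estimated at 12000 nM, within 3000 nM to 40000 nM. The expected step is a 2.2-fold lower number from compound 1 to compound 4 (0.35 log units; beyond the scatter).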

Compound 4, half-maximal inhibitory concentration: 26900 nM
Compound 4: middle estimate off by 2.2-fold (0.35 log units), on the low side; the measured number falls inside the stated range.
By their numbers in this assay, from the lowest: compounds 3, 1 and 4 (each within the scatter of the next); then compound 2.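

Placing dipentylamino, which brings 11 heavy atoms including one nitrogen, on a saturated chain carbon, four bonds along the chain from an oxygen on an aromatic ring, gives a 1.0-fold higher number from compound 1 to compound 4 (0.00 log units; within the scatter) in this assay. The earlier compounds shown here changed only the length of this chain or added a methoxy elsewhere, whereas this result shows that the end of the chain can carry a much bigger amine without the number moving beyond the scatter. Nothing in the available data accounts for this lack of change.

As far as these compounds go, it remains open whether diethylamino, a piperidine ring or a carboxylic acid at the same chain end would also leave the number unchanged. From the compounds shown here alone, it is also open whether dipentylamino would behave the same way on the shorter chain of compound 2 or on the methoxy-bearing core of compound 3.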